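A few compounds are considered here, and "the series" means these few. Any claim that something is new, unique, unknown or untested is made for them only; others in the source may bear on it.

Measured so far:
- compound 1, `CNc1nc(NCc2ccc(N(C)C(C)=O)cc2)cc(-c2ccccn2)n1`: 2610 nM
- compound 2, `CNc1nc(NCC(C)(C)C)cc(-c2ccccn2)n1`: 365 nM
- compound 3, `CN(C)c1nc(NCC2CC2)cc(-c2ccccn2)n1`: 6720 nM

In a functional assay on HEK293 cells for agonist activity at G-protein coupled receptor 39 (Mus musculus), read by inositol phosphate accumulation (a lower number here means that less compound is needed, a higher number that more compound is needed for the effect), compound 2 stands lowest of the three numbers shown. Compound 1 comes nearest, and its gap to compound 2 is already beyond the scatter; compound 3 lies furthest, also beyond the scatter. Among the measured compounds shown here, no two of the measured compounds differ in a single place, so no step between measured compounds can be stated, and the values can only be taken side by side.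

Compound 4, `CNc1nc(NCc2ccncc2)cc(-c2ccccn2)n1`, has not yet been measured in this assay. Against compound 2 the change is pyridin-4-yl in place of tert-butyl on a saturated chain carbon bound to a nitrogen on an aromatic ring.

For the measured compounds named here, the data hold no direct step for this change. Among the measured compounds, compound 1 carries an aromatic ring on the same saturated chain carbon and gives 2610 nM, while compound 2 with its neopentyl gives 365 nM; the move to a ring is therefore expected to cost potency, with a step from compound 2 to compound 4 of about a 4.1-fold higher number from compound 2 to compound 4 (0.61 log units; beyond the scatter). For compound 4 the estimate in this assay is 1500 nM, with a range from 400 nM to 6000 nM.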

Compound 4, half-maximal effective concentration: 304 nM
Beside the measured number, compound 4's estimate is 4.9-fold (0.69 log units) above it; the whole stated range lies above it.
By their numbers in this assay, from the lowest: compounds 4 and 2 (each within the scatter of the next); then compound 1; then compound 3.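

In this assay, among the compounds shown here, the change from neopentyl to (pyridin-4-yl)methyl gives a 1.2-fold lower number from compound 2 to compound 4 (0.08 log units; within the scatter) and is the first step that can be read in a single place. On this saturated chain carbon, pyridin-4-yl therefore stands level with tert-butyl, so the number here does not depend on having a branched alkyl group rather than an aromatic ring with a hetero atom. Nothing in hand offers an explanation for this result.

Still open, on these data alone, is how a plain phenyl or a morpholine on the same saturated chain carbon would read against these two compounds. Also open, as far as these compounds go, is whether a longer chain in place of the neopentyl would leave the number just as unchanged.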